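The source may report more compounds than this note shows. Statements on the series, on what has been measured and on what is new or still open speak of the compounds shown alone.

Compound 1 `CCOc1cc(C)c(-c2cccc(CNc3ccc(OCC(=O)O)c(F)c3)c2)c(C)c1` stands lowest among the two numbers obtained in a functional assay on CHO cells for agonist activity at Free fatty acid receptor 1 (Homo sapiens), read by FLIPR and calcium flux (a higher number here means that more compound is needed for the effect, a lower number that less compound is needed), where compound 1 gives 24.2 nM. Its closest neighbour is compound 3 `CCCOc1cc(C)c(-c2cccc(CNc3ccc(OCC(=O)O)c(F)c3)c2)c(C)c1`, which in this assay gives 38.7 nM; the step of a 1.6-fold higher number from compound 1 to compound 3 (0.20 log units; within the scatter) is within the scatter. Compound 2 `CCOc1cc(C)c(-c2cccc(COc3ccc(NCC(=O)O)c(F)c3)c2)c(C)c1` gives in this assay only a limit of the assay, > 1000 nM, so no number is known for it; this is the case described by the limit of > 1000 nM in this assay, at which 1 of the 3 values shown sits.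

Compound 4 `Cc1cc(OCCCS(C)(=O)=O)cc(C)c1-c1cccc(CNc2ccc(OCC(=O)O)c(F)c2)c1` is not yet measured. It differs from compound 1 by (methylsulfonyl)methyl in place of hydrogen on a saturated chain carbon, two bonds along the chain from an oxygen on an aromatic ring. For the measured compounds named here, the only measured step touching this same place on the chain is the small extension from compound 1 to compound 3, a 1.6-fold higher number from compound 1 to compound 3 (0.20 log units; within the scatter), which stayed within the scatter; the group entering here is larger and carries two hydrogen-bond acceptors, for which no measured step exists. The expectation is therefore a step in this assay of modest size, a 1.9-fold higher number from compound 1 to compound 4 (0.27 log units; within the scatter), with wide uncertainty. Compound 4 is estimated to give about 45 nM, in a range from 12 nM to 170 nM.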

Compound 4, half-maximal effective concentration: 59.8 nM
Beside the measured number, compound 4's estimate is 1.3-fold (0.12 log units) below it; the range from low to high includes it.
By their numbers in this assay, from the lowest: compounds 1, 3 and 4 (each within the scatter of the next, the first and the last beyond it). At a limit, above all of these: compound 2.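

Going from ethoxy to 3-(methylsulfonyl)propoxy brings a 2.5-fold higher number from compound 1 to compound 4 (0.39 log units; beyond the scatter) in this assay. For the compounds shown here, this is the first step at this place on the chain that lies beyond the scatter, yet it remains modest for an entering group of 5 heavy atoms with 2 hydrogen-bond acceptors. Taken alone, methylsulfonyl in place of hydrogen on the chain brings a 1.5-fold higher number from compound 3 to compound 4 (0.19 log units; within the scatter), so this end group adds no step that can be told from the scatter, and nothing shown here explains the size of either step.

The compounds shown leave open whether an amine or a carboxylic acid at the end of this chain would stay this close to compound 1. They also leave open whether a longer chain ending in methylsulfonyl would do so.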